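The source may report more compounds than this note shows. Statements on the series, on what has been measured and on what is new or still open speak of the compounds shown alone.

Of the compounds shown here, two have been tested in a functional assay on HepG2 cells (Homo sapiens) for antiproliferative activity, read by CCK-8 assay, with a stated time of 72 h, tested at 8 uM; a higher number here means a stronger effect of the compound at the concentration tested, a lower number a weaker effect. Compound 1 `COC(CCn1cnc2c(NCc3ccc(C(=O)Nc4ccccc4N)cc3)nc(Cl)nc21)OC` gives 34.2%, and compound 2 `Nc1ccccc1NC(=O)c1ccc(Cn2cnc3c(Nc4ccccc4)nc(Cl)nc32)cc1` gives 74.8%. Of these two numbers, compound 2 stands highest, and its gap to compound 1 lies beyond the usual scatter of the method. The two structures differ in more than one place, and no single step can be read between them.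

Compound 3 `Nc1ccccc1NC(=O)c1ccc(Cn2cnc3c(Nc4ccc(-c5ccccn5)cc4)nc(Cl)nc32)cc1` has not yet been measured in this assay. It differs from compound 2 in one place: pyridin-2-yl in place of hydrogen on an aromatic carbon. Among the compounds with values here, no measured pair shows a change of this kind, and the data give no direction for it. A step within the scatter, in either direction, appears most plausible. For compound 3 the expected value in this assay is 70%, with a range from 45% to 92%. This estimate means an expected step of a number 4.8 percentage points lower from compound 2 to compound 3 (within the scatter).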

Compound 3, a percentage reported as inhibition, at one concentration (the size of the read-out at that concentration, not a potency): 41.2%
Compound 3: the middle estimate sits 28.8 percentage points above what was measured; measured number outside the range, below it.
By their numbers in this assay, from the lowest: compounds 1 and 3 (each within the scatter of the next); then compound 2.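

The measurement in this assay shows that the aromatic carbon para to a large group on the phenyl of compound 2 is not a neutral place for a substituent. A step of a number 33.6 percentage points lower from compound 2 to compound 3 (beyond the scatter) follows when pyridin-2-yl takes the place of hydrogen there, so this single addition of one six-membered aromatic ring is enough to change the read-out by a large amount. No measurement shown gives a reason for this drop.

Going by these compounds, it remains open whether the loss belongs to any group at this carbon or to pyridin-2-yl in particular, since a single substitution cannot separate the two. A methyl, a fluorine, an amine or a plain phenyl at the same carbon would each help to show how much of the value of compound 2 can be kept.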